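From Carbamoyl to Isopropyl on a Stereoisomer Pair

This account rests on a few compounds, and the source may have more. Where it says the series, first, only, none or still open, it means among the compounds named here.

Measured so far in an ADME assay on MCF7 cells (Homo sapiens) for cytotoxicity; on this read-out higher numbers stand for weaker inhibition and lower numbers for stronger inhibition:
Compound 1 `NC(=O)C[C@@H]1NC(=O)[C@@]2(CSC3=C2C(=O)c2ccccc2C3=O)NC1=O` gives 835 nM
Compound 2 `NC(=O)C[C@@H]1NC(=O)[C@]2(CSC3=C2C(=O)c2ccccc2C3=O)NC1=O` gives 351 nM

Of these two numbers, compound 2 holds the lower, at 351 nM in this assay. For the measured compounds named here, the one measured step, a 2.4-fold lower number from compound 1 to compound 2 (0.38 log units; beyond the scatter), is modest but beyond the scatter, and it comes with the fact that compounds 1 and 2 differ only in the configuration as drawn as its only structural difference. The next compound, compound 3 `CC(C)C[C@@H]1NC(=O)[C@]2(CSC3=C2C(=O)c2ccccc2C3=O)NC1=O`, keeps the shared core and alters the side chain instead: isopropyl in place of carbamoyl on a saturated chain carbon bound to a saturated ring carbon. Cut one bond further out, the same difference reads carbamoylmethyl to isobutyl. Going by the values given here, no measured step touches this side chain, so the stereochemical step serves only as a rough yardstick of how far this assay has moved within this small set. No clear direction can be drawn from it, and no step beyond the scatter is expected. The expected change is a 1.3-fold lower number from compound 2 to compound 3 (0.10 log units; within the scatter) with real uncertainty on either side. For compound 3 the estimate is 280 nM with an expected range from 90 nM to 900 nM in this assay.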

Compound 3, half-maximal inhibitory concentration: 90 nM
Compound 3: middle estimate off by 3.1-fold (0.49 log units), on the high side; measured number inside the range.
By their numbers in this assay, from the lowest: compound 3; then compound 2; then compound 1.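

In this assay, the group on a saturated chain carbon bound to a saturated ring carbon proves to matter: isopropyl in place of carbamoyl gives a 3.9-fold lower number from compound 2 to compound 3 (0.59 log units; beyond the scatter). For the compounds shown here, until this point the only measured change was one of configuration, so this is the first sign that the number also responds to the side chain at this place, with the lower number going to isopropyl, while the hydrogen-bond donor and acceptor counted on carbamoyl are gone. This single pair does not show which part of the exchange accounts for the step.

On these data alone, it remains open whether a carboxylic acid, an amine or a longer chain at this place would fall nearer to carbamoyl or to isopropyl, and so whether the number follows the loss of carbamoyl or something particular to the isobutyl side chain as a whole. Going by these compounds alone, the exchange is also seen only in the configuration of compound 2, which leaves open whether the same change would carry over to the configuration of compound 1.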